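Extending the amide arm of compound 1 toward compound 4

The source may hold more compounds than are shown below. What is called first, only, known or untested is meant among the compounds shown, and "the series" means these compounds.

Measured so far:
- compound 1, `CNC(=O)Cn1c(-c2ccc(Cl)cc2)nc2cccnc21`: 12.5 mg/kg
- compound 2, `O=C(Cn1c(-c2ccc(Cl)cc2)nc2cccnc21)Nc1ccccn1`: 100 mg/kg
- compound 3, `O=C(Cn1c(-c2ccc(Cl)cc2)nc2cccnc21)Nc1cccnc1`: 100 mg/kg

All three share one core and differ only in the group carried on the amide-type nitrogen. In a functional assay on the whole organism with Mus musculus as the target (a higher number here means that more compound is needed for the effect, a lower number that less compound is needed), compound 1 gives 12.5 mg/kg, the lowest of the three numbers, so it needs the least compound for the effect. Compound 2 gives 100 mg/kg and compound 3 gives 100 mg/kg; the steps are an 8.0-fold higher number from compound 1 to compound 2 (0.90 log units; beyond the scatter) and an 8.0-fold higher number from compound 1 to compound 3 (0.90 log units; beyond the scatter), while no change at the digits printed from compound 2 to compound 3 (within the scatter).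

Compound 4, `CN(C)C(=O)CCn1c(-c2ccc(Cl)cc2)nc2cccnc21`, has not yet been tested. Compared with compound 1 it differs as follows: (dimethylcarbamoyl)methyl in place of methylcarbamoyl on a saturated chain carbon bound to an aromatic nitrogen. Within the data shown here, no measured pair follows exactly this change. The two steps that touch the same amide region both moved the number upward by a modest amount, and both replaced the hydrogen-bearing methyl amide with a larger group. Compound 4 also loses the amide hydrogen and grows by a further chain carbon and methyl, so a modest rise of the same kind seems the most likely outcome, though a smaller step cannot be excluded.

For compound 4 the expected value is therefore 30 mg/kg, within 10 mg/kg to 100 mg/kg, meaning an expected step of a 2.4-fold higher number from compound 1 to compound 4 (0.38 log units; beyond the scatter).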

Compound 4, dose for half-maximal effect: 29.4 mg/kg
For compound 4 the middle estimate is 1.0-fold (0.01 log units) above the measured one, within the range that was stated.
By their numbers in this assay, from the lowest: compound 1; then compound 4; then compounds 2 and 3 (each within the scatter of the next).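

In this assay the change from the methylcarbamoyl group to the (dimethylcarbamoyl)methyl group carries a cost beyond the scatter (a 2.4-fold higher number from compound 1 to compound 4 (0.37 log units; beyond the scatter)), so compound 1 keeps the lowest number of the four compounds. Even so, compound 4, the only one here whose amide nitrogen has no hydrogen and whose arm is the longer 2-(dimethylcarbamoyl)ethyl chain, gives a printed value (29.4 mg/kg) lower than that of compound 2 (100 mg/kg), so in this series an effect in the whole animal does not depend on keeping the amide hydrogen. No measurement shown here accounts for the size of this step.

As far as these compounds go, compound 4 differs from compound 1 in both the amide nitrogen and the chain length at once, so the share of each remains unknown; the 2-(methylcarbamoyl)ethyl group and a dimethylcarbamoyl group on the original shorter chain would separate the two. From the compounds shown here alone, whether the amide itself is needed also remains open, and a carboxylic acid or an amine at the end of the same chain would address that question.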